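This account rests on a few compounds, and the source may have more. Where it says the series, first, only, none or still open, it means among the compounds named here.

Within the data shown here, in a functional assay on B16 cells (Mus musculus) for inhibition (on this read-out higher numbers stand for weaker inhibition and lower numbers for stronger inhibition), compound 2 `CC(C)CN(CC(=O)NN(Cc1ccccc1)c1cnccn1)NC(=O)Cc1cccc(Br)c1` gives 23400 nM and stands at the upper end of the numbers so far. Compound 3 `CC(C)CN(CC(=O)N(CC(C)C)NC(=O)OCc1ccccc1)/N=C/c1ccccc1B(O)O` gives 26300 nM and lies within the scatter of compound 2. Compound 1 `CC(C)CN(CC(=O)NN(Cc1ccccc1)c1cnccn1)NC(=O)CBr` gives 11400 nM and has a clearly lower number than compound 2.

The next compound, compound 4 `CC(C)CN(CC(=O)NN(Cc1ccccc1)c1cnccn1)/N=C/c1cccc(B(O)O)c1`, differs from compound 2 by a group of 11 heavy atoms (7 carbon, 1 boron, 1 nitrogen, 2 oxygen; one six-membered aromatic ring of carbon only) in place of a group of 11 heavy atoms (8 carbon, 1 nitrogen, 1 oxygen, 1 bromine; one six-membered aromatic ring of carbon only), on an amine nitrogen in the structure. The incoming group therefore holds boron where the outgoing group holds bromine.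

Among the measured compounds shown here, only one measured step offers any guidance: a 2.1-fold higher number from compound 1 to compound 2 (0.31 log units; beyond the scatter) is modest. It swaps bromo for 3-bromophenyl on a saturated chain carbon bound to a carbonyl carbon, so it does not test boron at all. Compound 3 also holds boron, and its 26300 nM sits close to the number for compound 2, although it differs from compound 4 elsewhere too.

The expected change is a 1.2-fold lower number from compound 2 to compound 4 (0.07 log units; within the scatter) and so no step beyond the scatter is expected in this assay in either direction. For compound 4 the estimated value is 20000 nM within an expected range of 8000 nM to 50000 nM for now.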

Compound 4, half-maximal inhibitory concentration: > 80000 nM
Compound 4 was reported as a limit; the forecaster's own chance of this, stated with the estimate: 15%; middle value at least 4.0-fold (0.60 log units) away from the limit.
By their numbers in this assay, from the lowest: compound 1; then compounds 2 and 3 (each within the scatter of the next). At a limit, above all of these: compound 4.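

Compound 4 is reported only as a limit of the assay, not as a number: the limit of > 80000 nM in this assay, at which 1 of the 4 values shown sits.

Even so, the steps can be read as lower bounds: putting the boron-bearing group on the amine nitrogen gives an at least 3.4-fold higher number from compound 2 to compound 4 (0.53 log units; beyond the scatter), and the same comparison with the smaller bromine-bearing group of the other compound gives an at least 7.0-fold higher number from compound 1 to compound 4 (0.84 log units; beyond the scatter). Among these compounds, since higher numbers stand for weaker inhibition, this amine nitrogen does not accept every group of similar size equally, something the earlier compounds, which did not test this exchange, could not show.

The two groups differ in more than boron and bromine, so the compounds shown cannot tell which part of the exchange matters. A carboxylic acid in place of the boron-bearing part, on the same group, would help to separate these effects.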